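Cytotoxicity notes on triazolyl sulfonamides, compound 2 to 3

This account rests on a few compounds, and the source may have more. Where it says the series, first, only, none or still open, it means among the compounds named here.

Compound 1 `Cc1ccccc1-n1cc(-c2ccccc2NS(=O)(=O)c2c[nH]c(=O)[nH]c2=O)nn1` has been run in an ADME assay on L02 cells (Homo sapiens) for cytotoxicity, read by MTT assay, with a stated time of 24 h; a lower number here means that less compound is tolerated, a higher number that more compound is tolerated; in that assay compound 1 gives 56600 nM. Compound 2 `O=c1[nH]cc(S(=O)(=O)Nc2ccc(-c3cn(-c4ccccc4)nn3)cc2)c(=O)[nH]1` stands without a single number in this assay: the reported result for compound 2 is "not toxic" (no number reported), so all that can be said of where compound 2 stands is that no half-maximal cytotoxic concentration was resolved for it. Compound 3 `Cc1cccc(-n2cc(-c3ccc(NS(=O)(=O)c4c[nH]c(=O)[nH]c4=O)cc3)nn2)c1` is the next member of the series and remains to be measured in this assay. From compound 2 to compound 3 the structural change is methyl in place of hydrogen on an aromatic carbon. Within the data shown here, no measured step between two compounds differing in one place exists in this assay, so the size of this step cannot be taken from data; with compound 2 returning "not toxic" (no number reported) and compound 1 returning 56600 nM, no shift beyond the scatter is expected, and a well-tolerated outcome is anticipated. Compound 3 is therefore estimated in this assay at 60000 nM, within a range of 20000 nM to 200000 nM, with a real chance that only a non-toxic call and no number is reported.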

Compound 3, half-maximal cytotoxic concentration: 39000 nM
Compound 3: the middle estimate sits 1.5-fold (0.19 log units) above what was measured, within the range that was stated.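

No step can be read from compound 2 to compound 3 in this assay: compound 2 carries only a "not toxic" call, while compound 3 gives 39000 nM. The compounds shown leave open how far methyl in place of hydrogen on the aromatic carbon shifts tolerance in these cells. No supporting evidence bears on this result.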